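The source may report more compounds than this note shows. Statements on the series, on what has been measured and on what is new or still open speak of the compounds shown alone.

Measured so far in a functional assay on HEK293 cells (Homo sapiens) for cytotoxicity; on this read-out higher numbers stand for lower toxicity in this test and lower numbers for higher toxicity in this test:
- Compound 1 `COc1ccc([C@H]2CC(=O)N(Cc3cccc(C#N)c3)C2)cc1OC1CCCC1`: > 10000 nM
- Compound 2 `COc1ccc([C@H]2CC(=O)N(c3ccccc3)C2)cc1OC1CCCC1`: > 10000 nM

Both values are limits of the assay and not numbers.

In this assay compound 2 gives > 10000 nM, which is a limit. Among the measured compounds shown here, the same holds across the series so far, as the limit of > 10000 nM in this assay, at which 2 of the 2 values shown sit, records. Compound 3 `COc1ccc([C@H]2CC(=O)N(c3cccc(N(C)C)c3)C2)cc1OC1CCCC1` differs from compound 2 in one place: dimethylamino in place of hydrogen on an aromatic carbon, with dimethylamino in place of hydrogen on an aromatic carbon, meta to a large group. For the measured compounds named here, only one measured step exists, a step that the two limits leave unreadable from compound 1 to compound 2. It changes a different part of the structure and gives no size to carry over. With nothing to suggest a shift, no change beyond the scatter is expected, and the estimated step is a step that the limit leaves unreadable from compound 2 to compound 3. The most likely report for the new compound is again a limit. As a value, the estimate for compound 3 is 15000 nM, with an expected range of 5000 nM to 40000 nM.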

Compound 3, half-maximal cytotoxic concentration: > 10000 nM
Compound 3: a limit, no number; the forecaster's own chance of this, stated with the estimate: 85%; the middle value is on the limit's open side.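

In this assay compound 3 gives > 10000 nM, which is a limit and not a number. Among the compounds shown here, no new step can therefore be read from compound 1 or compound 2 to compound 3. The compounds shown leave open how far each lies beyond the value they share: the limit of > 10000 nM in this assay, at which 3 of the 3 values shown sit.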